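This account rests on a few compounds, and the source may have more. Where it says the series, first, only, none or still open, it means among the compounds named here.

Measured so far in a functional assay on NCI-H1975 cells (Homo sapiens) for cytotoxicity, read by CCK-8 assay, with a stated time of 72 h; on this read-out lower numbers stand for stronger inhibition and higher numbers for weaker inhibition:
compound 1 `C=CCn1c(=O)/c(=C\c2cccc(C)c2)[nH]c(=O)/c1=C\c1ccccc1OC` with 32800 nM;
compound 2 `COc1ccccc1/C=c1\c(=O)[nH]/c(=C/c2cccc(Cl)c2Cl)c(=O)n1C` with 300 nM;
compound 3 `C=CCn1c(=O)/c(=C\c2ccc(Cl)c(Cl)c2)[nH]c(=O)/c1=C\c1ccccc1` recorded as "not active" (no number reported), with no number.

Compound 2 has the lowest number of the two reported, and the gap to compound 1 lies well beyond the usual scatter. Compound 4 `COc1ccccc1/C=c1\c(=O)[nH]/c(=C/c2ccccc2Cl)c(=O)n1C` differs from compound 2 in a single place: hydrogen in place of chloro on an aromatic carbon. Within the data shown here, no pair of measured compounds differing in only one place is available, so the size of such a step is not known from these data. Since compound 2 already carries two chloro groups and is the strongest entry, taking one away is expected to weaken inhibition modestly, a step of a 3.3-fold higher number from compound 2 to compound 4 (0.52 log units; beyond the scatter). Compound 4 is therefore expected to give about 1000 nM, within 300 nM to 4000 nM.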

Compound 4, half-maximal inhibitory concentration: 200 nM
Compound 4: middle estimate off by 5.0-fold (0.70 log units), on the high side; the measured number lies below the stated range.
By their numbers in this assay, from the lowest: compounds 4 and 2 (each within the scatter of the next); then compound 1.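

In this assay, among these compounds, hydrogen in place of chloro, which turns 2,3-dichlorophenyl into 2-chlorophenyl, gives a 1.5-fold lower number from compound 2 to compound 4 (0.18 log units; within the scatter) as the first comparison here of compounds differing in one place. On this evidence, the chloro group at this position, ortho to the other chloro group, is not needed to keep the activity. No measurement available here explains this result.

Still open, going by these compounds, is whether the remaining chloro group matters. It is also unknown how an amine or a carboxylic acid on the same aromatic carbon would behave.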